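Swapping the triazinone base in an inactive lactone analogue

The source may report more compounds than this note shows. Statements on the series, on what has been measured and on what is new or still open speak of the compounds shown alone.

Measured so far:
compound 1, `Nc1ncn(CCC2(N)OC(=O)C(OCc3ccccc3)=C2OCc2ccccc2)c(=O)n1` — > 100000 nM
compound 2, `Nc1ncn(C/C=C2\OC(=O)C(OCc3ccccc3)=C2OCc2ccccc2)c(=O)n1` — 3490 nM
compound 3, `O=C1O[C@H]([C@@H](O)Cn2ccc(NC(=O)c3ccccc3)nc2=O)C(OCc2ccccc2)=C1OCc1ccccc1` — 4790 nM

All three were tested in a functional assay on MCF7 cells (Homo sapiens) for inhibition, read by MTT assay, with a stated time of 72 h; a lower number here means a stronger inhibitor, a higher number a weaker inhibitor. Compound 2 gives 3490 nM and compound 3 gives 4790 nM; both are numbers. In this assay compound 1 gives > 100000 nM, which is a limit of the assay and not a number. Compound 1 therefore stands at the limit of > 100000 nM in this assay, at which 1 of the 3 values shown sits, the weakest position the data can show, and nothing more precise can be said about it.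

The compound to be measured is compound 4, `Nc1ccn(CCC2(N)OC(=O)C(OCc3ccccc3)=C2OCc2ccccc2)c(=O)n1`. It differs from compound 1 by a group of 8 heavy atoms (4 carbon, 3 nitrogen, 1 oxygen; one six-membered aromatic ring with 2 hetero atoms) in place of a group of 8 heavy atoms (3 carbon, 4 nitrogen, 1 oxygen; one six-membered aromatic ring with 3 hetero atoms), on a saturated chain carbon, two bonds along the chain from a saturated ring carbon. Everything else, including the shared core with its two benzyl ether groups and the amino group on the saturated ring carbon, is kept.

Going by the values given here, no measured pair in this set shares exactly this change, so there is no measured step to lean on. Since compound 1 already sits at the limit, an exchange of one aromatic base for a closely related one is expected to move it only within the scatter, if at all, and most likely compound 4 will again come back as a limit. Compound 4 is expected to give 100000 nM, with a range from 20000 nM to 300000 nM. The expected step of a number no higher from compound 1 to compound 4 (the limit leaves the size open) is thus none beyond the scatter.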

Compound 4, half-maximal inhibitory concentration: 32000 nM
For compound 4 the middle estimate is 3.1-fold (0.49 log units) above the measured one, and the stated range covers the measured number.
By their numbers in this assay, from the lowest: compounds 2 and 3 (each within the scatter of the next); then compound 4. At a limit, above all of these: compound 1.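

In this assay, going by these compounds alone, the exchange of the base gives an at least 3.1-fold lower number from compound 1 to compound 4 (0.49 log units; beyond the scatter), which is the first step in this set that can be read at all. It shows that the base on this saturated chain carbon, two bonds along the chain from a saturated ring carbon, matters for the number: a six-membered aromatic ring with 2 hetero atoms in place of one with 3 hetero atoms is enough to bring a measurable number, although the two groups have the same count of heavy atoms and the shared core, with its two benzyl ether groups and its amino group, stays the same. From the compounds shown here alone, the true size of the step stays unknown, as the value for compound 1 is a limit of the assay and not a number: the limit of > 100000 nM in this assay, at which 1 of the 4 values shown sits.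

The compounds shown leave open whether a larger base, such as adenine, or a methyl group on the amino group of the base would lower the number further at this place. They also leave open whether a longer chain between the base and the saturated ring carbon would keep the gain seen with this base.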